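The source may hold more compounds than are shown below. What is called first, only, known or untested is meant among the compounds shown, and "the series" means these compounds.

Compound 1 `O=S(=O)(/C=C/c1ccccn1)c1ccccc1F` and compound 2 `O=S(=O)(/C=C/c1ncccc1Cl)c1ccccc1F` share one core and differ in a single place: chloro in place of hydrogen on an aromatic carbon In an assay on U2OS cells for activation of nuclear factor erythroid 2-related factor 2 (Homo sapiens), read by beta-arrestin recruitment, with a stated time of 6 h (on this read-out lower numbers stand for an effect already at smaller amounts and higher numbers for an effect only at larger amounts of compound), compound 1 gives 1050 nM, while compound 2 gives 30 nM, so that the chloro brings a 35-fold lower number from compound 1 to compound 2 (1.54 log units; beyond the scatter). Compound 3 `O=S(=O)(/C=C/c1ccccn1)c1cccc(Cl)c1` carries another core; the difference between the core of compound 1 and the core of compound 3 is not broken down here. In this assay compound 3 gives 1430 nM, a number that stands close to that of compound 1 and far from that of compound 2.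

Compound 4 `O=S(=O)(/C=C/c1cccc(Cl)n1)c1cccc(Cl)c1` has not yet been measured. Among the measured compounds shown here, it differs from compound 3 in one place: chloro in place of hydrogen on an aromatic carbon This is the same kind of change as the one between compound 1 and compound 2, but not the same change: in compound 2 the chloro sits ortho to a large group and two atoms from the ring nitrogen, whereas in compound 4 it sits next to the ring nitrogen and meta to a large group. For the measured compounds named here, the only guide available is a 35-fold lower number from compound 1 to compound 2 (1.54 log units; beyond the scatter), and there the chloro stood at a different place. In this assay the expected step is therefore a 3.6-fold lower number from compound 3 to compound 4 (0.55 log units; beyond the scatter), more modest than the earlier one, with wide uncertainty. Compound 4 is thus estimated to give 400 nM, most likely falling between 100 nM and 1500 nM.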

Compound 4, half-maximal effective concentration: 1070 nM
Estimate against measurement, compound 4: 2.7-fold (0.43 log units) below, and the stated range covers the measured number.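

In this assay the new step is a 1.3-fold lower number from compound 3 to compound 4 (0.13 log units; within the scatter) and so stays within the usual scatter, whereas the same kind of change brought a large step on the core of compound 1. The two steps do not agree: the same change on two cores in this assay, a 35-fold lower number (1.54 log units; beyond the scatter) from compound 1 to compound 2 and a 1.3-fold lower number (0.13 log units; within the scatter) from compound 3 to compound 4, 26-fold (1.42 log units) apart, beyond the scatter of two such steps.

A chloro in place of a hydrogen therefore cannot be counted on to bring the same gain wherever it is added in this series, and the large step seen with compound 2 does not carry over to compound 4. What this does not show is the reason for the gap: the chloro in compound 4 stands next to the ring nitrogen and meta to a large group, at a different place from the chloro in compound 2, and the cores differ as well, so the place and the core cannot be told apart with these compounds.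

From the compounds shown here alone, it remains open whether a chloro at the place it holds in compound 2 would bring a large step on the core of compound 3, and whether the place it holds in compound 4 would do so on the core of compound 1. Going by these compounds, it is also open how a methyl group, a methoxy group or an amine would compare with the chloro at either place.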